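A few compounds are considered here, and "the series" means these few. Any claim that something is new, unique, unknown or untested is made for them only; others in the source may bear on it.

Measured compounds in an assay on brain for displacement of a labelled ligand from Sigma non-opioid intracellular receptor 1 (Cavia porcellus); on this read-out higher numbers stand for weaker inhibition and lower numbers for stronger inhibition:
compound 1 `CC(C)(C)[C@]1(c2ccccc2)OCC[C@H](CCN)O1` gives only a limit of the assay, > 10000 nM.
compound 2 `CC(C)(C)[C@]1(c2ccccc2)OCC[C@H](CCNCc2ccccc2)O1` gives 253 nM.
compound 3 `C[C@@]1(c2ccccc2)OCC[C@@H](CCN)O1` gives only a limit of the assay, > 10000 nM.

Compound 1 stands at the limit, where two of the three values sit (the limit of > 10000 nM in this assay, at which 2 of the 3 values shown sit). Going by the values given here, the only measured step, an at least 39-fold lower number from compound 1 to compound 2 (1.59 log units; beyond the scatter), changes the amine nitrogen and not the ring carbon. Compound 4 `CCC[C@]1(c2ccccc2)OCC[C@H](CCN)O1` differs from compound 1 by propyl in place of tert-butyl on a saturated ring carbon. Among the compounds with values here, no measured step bears on this change. Compound 3, which keeps the 2-aminoethyl group and carries a different group on the saturated ring carbon, gives only a limit. The expected step is a step that the limit leaves unreadable from compound 1 to compound 4, none beyond the scatter, with the value staying at the limit. Compound 4 is estimated at 20000 nM, between 5000 nM and 100000 nM.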

Compound 4, inhibition constant: > 10000 nM
Compound 4 was reported as a limit (the forecaster's own chance of this, stated with the estimate: 80%); the middle value is on the limit's open side.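

No step can be read between compound 1 and compound 4, since both are reported only as the same limit: the limit of > 10000 nM in this assay, at which 3 of the 4 values shown sit.

The compounds shown leave open whether propyl and tert-butyl on the saturated ring carbon differ at all when values fall within the measurable range.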